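Methoxy additions on the chalcone-type pyrazole series

The source may report more compounds than this note shows. Statements on the series, on what has been measured and on what is new or still open speak of the compounds shown alone.

Compound 1 `COc1ccc(-c2cc(/C=C/C(=O)c3ccc(N)cc3)[nH]n2)cc1` in a functional assay on M14 cells (Homo sapiens) for inhibition, read by sulforhodamine B assay, with a stated time of 48 h (on this read-out lower numbers stand for higher toxicity in this test and higher numbers for lower toxicity in this test), gives 36100 nM. Compound 3 `COc1ccc(-c2cc(/C=C/C(=O)c3ccc(N)cc3)[nH]n2)cc1OC` gives 15000 nM in this assay, and the pair differs by methoxy in place of hydrogen on an aromatic carbon; the step is a 2.4-fold lower number from compound 1 to compound 3 (0.38 log units; beyond the scatter). Compound 2 `COc1ccc(C(=O)/C=C/c2cc(-c3cc(OC)c(OC)c(OC)c3)n[nH]2)cc1OC` gives 7380 nM, the lowest number of the three; the difference between the core of compound 2 and the core of compound 1 is not broken down here. Compound 4 `COc1cc(C(=O)/C=C/c2cc(-c3cc(OC)c(OC)c(OC)c3)n[nH]2)cc(OC)c1OC` is not yet measured. It differs from compound 2 by methoxy in place of hydrogen on an aromatic carbon, the same kind of change as from compound 1 to compound 3, though here the place is also meta to a methoxy group. Resting on a 2.4-fold lower number from compound 1 to compound 3 (0.38 log units; beyond the scatter), the step from compound 2 to compound 4 is expected to be a 1.6-fold lower number from compound 2 to compound 4 (0.21 log units; within the scatter). Compound 4 is estimated at 4500 nM, between 1800 nM and 11000 nM.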

Compound 4, concentration lethal to 50% of the cells: 6130 nM
For compound 4 the middle estimate is 1.4-fold (0.13 log units) below the measured one; low and high end bracket the measured number.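

In this assay, adding the methoxy gives a 1.2-fold lower number from compound 2 to compound 4 (0.08 log units; within the scatter), while on the core of compound 1 the same change gave a 2.4-fold lower number from compound 1 to compound 3 (0.38 log units; beyond the scatter). The two steps cannot be told apart: the same change on two cores in this assay, a 2.4-fold lower number (0.38 log units; beyond the scatter) from compound 1 to compound 3 and a 1.2-fold lower number (0.08 log units; within the scatter) from compound 2 to compound 4, 2.0-fold (0.30 log units) apart, within the scatter of two such steps This fits the change carrying over from one core to the other, but two pairs in a single assay do not establish that it does, and the step on its own shows no clear effect on the core of compound 2.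

Still open, from the compounds shown here alone, is whether an ethoxy group or a carboxylic acid in the same place would shift the number on either core. Also open, going by these compounds, is whether the methoxy step would hold on a core outside these two.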